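The source may report more compounds than this note shows. Statements on the series, on what has been measured and on what is new or still open speak of the compounds shown alone.

In a functional assay on 1-87 cells (Homo sapiens) for cytotoxicity (a lower number here means a stronger inhibitor, a higher number a weaker inhibitor), compound 1 (`COc1ccc(/C=C\c2cc(OC)c(OC)c(OC)c2)cc1B(O)O`) gives 13 nM. Compound 2 (`COc1cc(/C=C\c2ccc(B(O)O)cc2)cc(OC)c1OC`) gives 3200 nM, the higher of the two numbers, which makes it the weaker inhibitor of the pair, with a gap to compound 1 well beyond the scatter.

Compound 3 (`COc1cc(/C=C\c2ccc(B(O)O)cc2)cc(OC)c1`) has not yet been measured in this assay. It follows from compound 2 by one change: hydrogen in place of methoxy on an aromatic carbon, ortho to two methoxy groups and para to a large group (hydrogen in place of methoxy on an aromatic carbon).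

Within the data shown here, no measured pair isolates this change, so there is no direct precedent for its size. Among the measured compounds shown here, the two available values show only that numbers can span a wide range. Starting from compound 2 at 3200 nM, the working expectation is a move towards a higher number and weaker inhibition, not a gain, although this is a judgement and the uncertainty is wide. The estimated shift is a 3.1-fold higher number from compound 2 to compound 3 (0.49 log units; beyond the scatter), expected to lie beyond the scatter. For compound 3 the expected value is 10000 nM, with an estimated range of 3000 nM to 40000 nM.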

Compound 3, half-maximal inhibitory concentration: 9100 nM
Estimate against measurement, compound 3: 1.1-fold (0.04 log units) above; the range from low to high includes it.
By their numbers in this assay, from the lowest: compound 1; then compound 2; then compound 3.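

In this assay hydrogen in place of methoxy gives a 2.8-fold higher number from compound 2 to compound 3 (0.45 log units; beyond the scatter) on this aromatic carbon, ortho to two methoxy groups and para to a large group. Among these compounds, this is the first comparison that isolates a single place, and it shows that this methoxy still counts for inhibition in a compound already as weak as compound 2 at 3200 nM, although the loss is modest. No measurement at hand bears on what lies behind this step.

The compounds shown do not tell whether a hydroxyl, a fluorine or an ethoxy on that same carbon would behave like methoxy or like hydrogen, so it remains unclear how specific the requirement at this position is. As far as these compounds go, it also stays open whether the same change would carry a step of similar size in the much stronger setting of compound 1 at 13 nM, since the present step comes only from the weak end of the series.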